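This account rests on a few compounds, and the source may have more. Where it says the series, first, only, none or still open, it means among the compounds named here.

Measured in an ADME assay on microsomes from liver (Rattus norvegicus) for metabolic stability, read by LC-MS, using NADPH, with a stated time of 30 min, tested at 1 uM; on this read-out higher numbers stand for fast clearance and lower numbers for slow clearance:
- Compound 1 `CC(C)c1noc(N2CCC(Oc3cc(N4CCc5cc(C6CCCCC6=O)ccc54)ncn3)CC2)n1`: 141 mL.min-1.g-1
- Compound 2 `CC(C)c1noc(N2CCC(Oc3cc(N4CCc5cc(N6CCCNS6(=O)=O)ccc54)ncn3)CC2)n1`: 21 mL.min-1.g-1
- Compound 3 `CC(C)c1noc(N2CCC(Oc3cc(N4CCc5cc(N6CCCC6=O)ccc54)ncn3)CC2)n1`: 138 mL.min-1.g-1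

Compound 3 sits at the high end of these numbers. The data show a 1.0-fold lower number from compound 1 to compound 3 (0.01 log units; within the scatter), and also a 6.6-fold higher number from compound 2 to compound 3 (0.82 log units; beyond the scatter). Compound 4 `CC(C)c1noc(N2CCC(Oc3cc(N4CCc5cc(N6CCOCC6=O)ccc54)ncn3)CC2)n1` carries 3-oxomorpholin-4-yl in place of 2-oxopyrrolidin-1-yl on an aromatic carbon. Within the data shown here, no measured step makes this exact exchange, but the steps at the same place give some guidance. Exchanging one ring for another does not always move the number, as a 1.0-fold lower number from compound 1 to compound 3 (0.01 log units; within the scatter) shows. The larger move is a 6.7-fold lower number from compound 1 to compound 2 (0.83 log units; beyond the scatter), and it ends at a group whose ring has 3 hetero atoms. The entering 3-oxomorpholin-4-yl is not that group, so only a part of that move is expected here, and one compound is thin support. The expected change is a 1.8-fold lower number from compound 3 to compound 4 (0.26 log units; within the scatter), a small step toward lower numbers that may not clear the scatter. Compound 4 is estimated at 75 mL.min-1.g-1, with an expected range from 30 mL.min-1.g-1 to 160 mL.min-1.g-1.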

Compound 4, intrinsic clearance in microsomes: 46 mL.min-1.g-1
Compound 4: middle estimate off by 1.6-fold (0.21 log units), on the high side; low and high end bracket the measured number.
By their numbers in this assay, from the lowest: compound 2; then compound 4; then compounds 3 and 1 (each within the scatter of the next).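

At this aromatic carbon, 3-oxomorpholin-4-yl in place of 2-oxopyrrolidin-1-yl gives in this assay a 3.0-fold lower number from compound 3 to compound 4 (0.48 log units; beyond the scatter), so a ring exchange here can move the number even though the exchange between compounds 1 and 3 did not. The same group gives a 3.1-fold lower number from compound 1 to compound 4 (0.49 log units; beyond the scatter), while the ring with 3 hetero atoms still stands apart from it, with a 2.2-fold higher number from compound 2 to compound 4 (0.34 log units; beyond the scatter). Across the compounds shown, more hetero atoms in this ring go with a lower number, except that compound 1 and compound 3 lie within the scatter of each other.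

Nothing measured here accounts for the fall in the number. On these data alone, whether ring size or the ring oxygen carries the step stays open, and 2-oxopiperidin-1-yl, a six-membered ring without that oxygen, would separate the two.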